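The source may report more compounds than this note shows. Statements on the series, on what has been measured and on what is new or still open speak of the compounds shown alone.

Measured in an assay on cells (Oocyte) for negative allosteric modulation of glutamate receptor ionotropic, NMDA 2D (Rattus norvegicus), read by two-electrode voltage clamp; on this read-out higher numbers stand for weaker inhibition and lower numbers for stronger inhibition:

- compound 1, `O=C(O)CCC(=O)N1N=C(c2c(-c3ccc(Cl)cc3)c3ccccc3[nH]c2=O)CC1c1ccccc1`: 11000 nM
- compound 2, `O=C(O)CCC(=O)N1N=C(c2c(-c3ccc(C(F)(F)F)cc3)c3ccccc3[nH]c2=O)CC1c1ccc(Cl)cc1`: 2800 nM
- compound 3, `COc1cccc(-c2c(C3=NN(C(=O)CCC(=O)O)C(c4ccc(Cl)cc4)C3)c(=O)[nH]c3ccccc23)c1`: 4500 nM

Compound 3 gives the second highest of the three numbers. Its nearest neighbour is compound 2, and the step of a 1.6-fold higher number from compound 2 to compound 3 (0.21 log units; within the scatter) lies within the scatter, so the two cannot be ordered. Compound 1 sits furthest off, with a higher number than compound 3, beyond the scatter.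

Compound 4, `O=C(O)CCC(=O)N1N=C(c2c(-c3cc(Cl)cc(Cl)c3)c3ccccc3[nH]c2=O)CC1c1ccc(Cl)cc1`, has not yet been measured in this assay. It differs from compound 3 in one place: 3,5-dichlorophenyl in place of 3-methoxyphenyl on an aromatic carbon. Going by the values given here, the only measured step that bears on this position is the one from compound 2 to compound 3, an exchange of one aryl group for another at the same place, and that step stayed within the scatter. Among the compounds with values here, no measured pair involves a dichlorophenyl group or a chlorine in place of a methoxy group, so there is nothing to point to a shift in either direction. The expected step is therefore a 1.3-fold lower number from compound 3 to compound 4 (0.11 log units; within the scatter), none beyond the scatter. For compound 4 the estimate in this assay is 3500 nM, with a range from 1200 nM to 10000 nM.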

Compound 4, half-maximal inhibitory concentration: 700 nM
For compound 4 the middle estimate is 5.0-fold (0.70 log units) above the measured one, and the stated range ends above it.
By their numbers in this assay, from the lowest: compound 4; then compounds 2 and 3 (each within the scatter of the next); then compound 1.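

In this assay the exchange of aryl groups on this aromatic carbon can shift the number beyond the scatter: 3,5-dichlorophenyl gives a 6.4-fold lower number from compound 3 to compound 4 (0.81 log units; beyond the scatter) against 3-methoxyphenyl and a 4.0-fold lower number from compound 2 to compound 4 (0.60 log units; beyond the scatter) against 4-(trifluoromethyl)phenyl. Going by these compounds alone, the one exchange available before, a 1.6-fold higher number from compound 2 to compound 3 (0.21 log units; within the scatter) between those two groups, stayed within the scatter and so gave no sign of how far this position can respond. Nothing at hand bears on why 3,5-dichlorophenyl behaves differently here.

Open, going by these compounds, is whether one chlorine carries the step or both are needed, which 3-chlorophenyl would tell, and whether 3,5-dimethylphenyl or 3,5-dimethoxyphenyl would go the same way. On these data alone, all these steps also share the rest of the molecule, so their size with a different group elsewhere remains unknown.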